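Cytotoxicity Notes: From Compound 2 to Compound 3

The compounds below may be only part of what the source reports. "The series", "measured", "known", "first", "only" and "open" are said of these compounds alone.

The series shares the core of compound 1 `CN(C)CCn1cnnc1-c1cc(Oc2ccc(NC(=O)N/N=C/c3ccccc3O[N+](=O)[O-])cc2F)ccn1` and varies the group on the carbon with a double bond to nitrogen. In an ADME assay on WI-38 cells (Homo sapiens) for cytotoxicity, read by MTT assay, with a stated time of 72 h (on this read-out higher numbers stand for weaker inhibition and lower numbers for stronger inhibition), compound 1 gives 6860 nM. Among the compounds with values here, compound 2 `COc1ccc(/C=N/NC(=O)Nc2ccc(Oc3ccnc(-c4nncn4CCN(C)C)c3)c(F)c2)cc1O` carries the 3-hydroxy-4-methoxyphenyl group; in this assay compound 2 gives "not determined" (no result reported), so there is no single number for compound 2 and no measured step from it to any other member. Compound 3 `CN(C)CCn1cnnc1-c1cc(Oc2ccc(NC(=O)N/N=C/c3ccc(F)cc3Cl)cc2F)ccn1` differs from compound 2 by 2-chloro-4-fluorophenyl in place of 3-hydroxy-4-methoxyphenyl on a carbon with a double bond to nitrogen. Within the data shown here, no step between measured compounds exists, so the direction of this change in this assay cannot be read from the data; the only anchor is compound 1, and no step beyond the scatter is assumed. Compound 3 is expected to give about 7000 nM in this assay, with a range of 2000 nM to 25000 nM.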

Compound 3, half-maximal inhibitory concentration: 2090 nM
Compound 3: middle estimate off by 3.3-fold (0.52 log units), on the high side; the range from low to high includes it.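

In this assay, the group on a carbon with a double bond to nitrogen now has its first measured step: with the shared core unchanged, 2-chloro-4-fluorophenyl in place of 2-(nitrooxy)phenyl goes with a 3.3-fold lower number from compound 1 to compound 3 (0.52 log units; beyond the scatter). The step lies beyond the usual scatter and points toward stronger inhibition, so this place can shift the read-out, though this rests on a single pair. No measurement at hand explains the step.

Steps involving compound 2 cannot be read, so the effect of replacing 3-hydroxy-4-methoxyphenyl with 2-chloro-4-fluorophenyl stays unknown. Also open, on these data alone, are the separate contributions of the chlorine and the fluorine, and how a phenyl group carrying an amine or a carboxylic acid would read at this place.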